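This account rests on a few compounds, and the source may have more. Where it says the series, first, only, none or still open, it means among the compounds named here.

Compound 1, `O=C(CCCCCCc1ccccc1)N1CCCC1`, gives 12900 nM in an assay on HEK293 cells for inhibition of N-acylethanolamine-hydrolyzing acid amidase (Rattus norvegicus), read by LC-MS, with a stated time of 30 min; a higher number here means a weaker inhibitor, a lower number a stronger inhibitor.
Compound 2, `O=C(CCc1ccc(-c2ccc(F)cc2)cc1)N1CCCC1`, gives 3400 nM in this assay.

Of the two measured compounds, compound 2 stands at the lower number in this assay, and its gap to compound 1 is beyond the usual scatter. The unmeasured compound 3, `O=C(CCc1ccc(Oc2ccccc2)cc1)N1CCCC1`, differs from compound 2 in one place: phenoxy in place of 4-fluorophenyl on an aromatic carbon. For the measured compounds named here, no measured pair shows this change, so the direction rests on judgment alone. Compound 3 is expected to stay close to compound 2, with a step of a 1.4-fold lower number from compound 2 to compound 3 (0.13 log units; within the scatter) at most modestly downward. The estimate for compound 3 is 2500 nM, between 800 nM and 8000 nM.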

Compound 3, half-maximal inhibitory concentration: > 100000 nM
Compound 3 gave a limit, no number; the forecaster's own chance of this, stated with the estimate: 3%; at least 40-fold (1.60 log units) between middle value and limit.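

Compound 3 carries a limit of the assay, not a number, and it alone of the compounds shown sits there: the limit of > 100000 nM in this assay, at which 1 of the 3 values shown sits. Phenoxy in place of 4-fluorophenyl gives an at least 29-fold higher number from compound 2 to compound 3 (1.46 log units; beyond the scatter), so this aromatic carbon proves sensitive to the group it carries, even though both groups hold the same count of heavy atoms. Phenoxy also brings a hydrogen-bond acceptor that 4-fluorophenyl lacks.

The compounds shown do not separate the effect of the oxygen from that of the missing fluorine. A 4-fluorophenoxy group or a benzyl group at this carbon would bear directly on that question.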